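Series notes: toxicity across an aryl propargylamide set

This account rests on a few compounds, and the source may have more. Where it says the series, first, only, none or still open, it means among the compounds named here.

Compound 2 `C#CCNC(=O)/C(C)=C(\C)c1ccccc1` carries hydrogen on the aromatic carbon where the other two members carry a substituent. In a toxicity assay on the whole organism (strain Icem-CET (SPF Caw)) for cytotoxicity, with Mus musculus as the target (a lower number here means that less compound is needed, a higher number that more compound is needed for the effect), compound 2 gives 400 mg/kg. Compound 1 `C#CCNC(=O)/C(C)=C(\C)c1ccc(OC)cc1` carries methoxy on that aromatic carbon; in this assay compound 1 gives 400 mg/kg, and no change at the digits printed from compound 1 to compound 2 (within the scatter). Compound 3 `C#CCNC(=O)/C(C)=C(\C)c1ccc(C)cc1` carries methyl on that aromatic carbon; in this assay compound 3 gives 200 mg/kg. The steps of a 2.0-fold lower number from compound 1 to compound 3 (0.30 log units; within the scatter) and a 2.0-fold lower number from compound 2 to compound 3 (0.30 log units; within the scatter) likewise stay within the scatter. Compound 2 thus stands level with compound 1 at the digits shown; its nearest neighbour is compound 1, its furthest compound 3, and even that gap lies within the scatter.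

Compound 4 `C=CCNC(=O)/C(C)=C(\C)c1ccccc1` differs from compound 2 by vinyl in place of ethynyl on a saturated chain carbon bound to an amide-type nitrogen. None of the three measured steps bears on this part of the molecule: each of them alters the group on an aromatic carbon and leaves the propargylamino chain untouched. Going by the values given here, the measured set therefore offers no step that speaks for or against a shift in this assay on going from propargyl to allyl, and the three steps it does hold are all within the scatter. The working expectation for compound 4 is accordingly no step beyond the scatter, that is no change at the digits printed from compound 2 to compound 4 (within the scatter). Compound 4 is estimated at 400 mg/kg, with a range from 200 mg/kg to 800 mg/kg.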

Compound 4, dose for half-maximal effect: 300 mg/kg
Estimate against measurement, compound 4: 1.3-fold (0.12 log units) above; measured number inside the range.
By their numbers in this assay, from the lowest: compounds 3, 4, 1 and 2 (each within the scatter of the next).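

Working notes on the chain: compound 4 is the first compound in the series to vary the propargylamino chain, since every earlier step altered only the group on an aromatic carbon. In this assay the change to allylamino gives a 1.3-fold lower number from compound 2 to compound 4 (0.12 log units; within the scatter) and so stays within the scatter, which shows that with hydrogen on the aromatic carbon, a double bond can stand in place of the triple bond outside aromatic rings without a step beyond the scatter in this toxicity read-out. Nothing measured alongside this step bears on it, and the result carries no explanation.

The compounds shown leave open whether vinyl in place of ethynyl reads the same way when methoxy or methyl sits on the aromatic carbon, as the allylamino chain appears here only with hydrogen there. They also leave open how the read-out responds at this position to a fully saturated propyl chain, a longer chain, or a chain ending in an amine or a carboxylic acid.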